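A few compounds are considered here, and "the series" means these few. Any claim that something is new, unique, unknown or untested is made for them only; others in the source may bear on it.

Compound 1 `CN1CC2(C1)CN(c1ccc(OCc3ccccc3)c(C(=O)Nc3ccnnc3)c1)C2`: 25.1 nM
Compound 2 `O=C(Nc1ccnnc1)c1cc(N2CCC(F)CC2)ccc1OCc1ccccc1`: 39.8 nM

In an assay on Sf9 cells for inhibition of Leucine-rich repeat serine/threonine-protein kinase 2 (Homo sapiens), read by TR-FRET, with stated times of 30 min and 2 h (a higher number here means a weaker inhibitor, a lower number a stronger inhibitor), compound 2 gives 39.8 nM, and compound 1 gives 25.1 nM; the step of a 1.6-fold higher number from compound 1 to compound 2 (0.20 log units; within the scatter) lies within the scatter, so neither compound stands apart from the other. Compound 3 `N#CC1CCN(c2ccc(OCc3ccccc3)c(C(=O)Nc3ccnnc3)c2)CC1` differs from compound 2 by cyano in place of fluoro on a saturated ring carbon. Within the data shown here, no measured step touches this position; the only step known, a 1.6-fold higher number from compound 1 to compound 2 (0.20 log units; within the scatter), swapped a whole ring and stayed within the scatter. With nothing pointing either way, no movement beyond the scatter is expected. Compound 3 is estimated at 40 nM, between 15 nM and 110 nM, which would mean a 1.0-fold higher number from compound 2 to compound 3 (0.00 log units; within the scatter).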

Compound 3, half-maximal inhibitory concentration: 10 nM
Beside the measured number, compound 3's estimate is 4.0-fold (0.60 log units) above it, outside the stated range (below it).
By their numbers in this assay, from the lowest: compound 3; then compounds 1 and 2 (each within the scatter of the next).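

In this assay, replacing fluoro with cyano on this saturated ring carbon gives a 4.0-fold lower number from compound 2 to compound 3 (0.60 log units; beyond the scatter), so a small change at this one position can shift the number beyond the scatter, which the earlier ring swap did not do. The 4-cyanopiperidin-1-yl group also separates from the group on compound 1, with a 2.5-fold lower number from compound 1 to compound 3 (0.40 log units; beyond the scatter). No available evidence explains this difference.

Going by these compounds, whether cyano is unusual here remains open, since only fluoro and cyano are compared at this carbon. A carboxylic acid, an amine or a cyanomethyl group there would show how far the trend extends.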